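Swapping a Methylphenyl for a Difluorophenyl on a Shared Core

The source may report more compounds than this note shows. Statements on the series, on what has been measured and on what is new or still open speak of the compounds shown alone.

Compound 3 `COc1ccc2[nH]cc(C(c3ccc(C)cc3)c3c[nH]c4ccc(OC)cc34)c2c1` lies at the high end of the three numbers in an ADME assay on WS1 cells (Homo sapiens) for cytotoxicity, read by MTT assay, with a stated time of 48 h (a higher number here means a weaker inhibitor, a lower number a stronger inhibitor), giving 38600000 nM. Compound 2 `Fc1cc(F)cc(C(c2c[nH]c3ccc(I)cc23)c2c[nH]c3ccc(I)cc23)c1` gives 28500000 nM, a gap within the scatter, while compound 1 `Ic1ccc2[nH]cc(Cc3c[nH]c4ccc(I)cc34)c2c1` gives 13000000 nM, a gap beyond it. Compound 4 `COc1ccc2[nH]cc(C(c3cc(F)cc(F)c3)c3c[nH]c4ccc(OC)cc34)c2c1` differs from compound 3 by 3,5-difluorophenyl in place of 4-methylphenyl on a saturated chain carbon bound to two aromatic carbons. Going by the values given here, the only measured step involving this entering group is a 2.2-fold higher number from compound 1 to compound 2 (0.34 log units; beyond the scatter), yet there the 3,5-difluorophenyl replaced a hydrogen rather than another aryl group, so it bears only loosely on the present change. On that basis the expected step is a 1.1-fold lower number from compound 3 to compound 4 (0.04 log units; within the scatter), with nothing beyond the scatter anticipated. Compound 4 is accordingly estimated at 35000000 nM, within a range of 15000000 nM to 80000000 nM.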

Compound 4, half-maximal inhibitory concentration: 26500000 nM
For compound 4 the middle estimate is 1.3-fold (0.12 log units) above the measured one, and the stated range covers the measured number.
By their numbers in this assay, from the lowest: compound 1; then compounds 4, 2 and 3 (each within the scatter of the next).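

Until now this saturated chain carbon had only been seen changing from hydrogen to an aryl group, whereas compound 3 and compound 4 exchange one aryl group for another. In this assay this exchange gives a 1.5-fold lower number from compound 3 to compound 4 (0.16 log units; within the scatter) and so shows that, on this shared core, 3,5-difluorophenyl and 4-methylphenyl cannot be told apart. Nothing available offers a reason for this result. Still open, on these data alone, is what an amine or a carboxylic acid at this carbon would do to the number, and whether hydrogen there on the core of compound 3 would give a step like that seen on the core of compound 1.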